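The source may hold more compounds than are shown below. What is called first, only, known or untested is meant among the compounds shown, and "the series" means these compounds.

Measured in an ADME assay on H9c2 cells (Rattus norvegicus) for cytotoxicity; on this read-out lower numbers stand for stronger inhibition and higher numbers for weaker inhibition:
- Compound 1 `O=C(Nc1nc2ccc(C(F)(F)F)cc2s1)C1CC1`: > 50000 nM (a limit, not a number)
- Compound 2 `CCCC(=O)Nc1nc2ccc(Cl)cc2s1`: > 50000 nM (a limit, not a number)

For the measured compounds named here, neither compound gives a number, and they differ in more than one place, so no measured step is available in this assay. The whole record so far is the limit of > 50000 nM in this assay, at which 2 of the 2 values shown sit.

Compound 2 is the reference for the next step. In this assay compound 2 stands at > 50000 nM, which is a limit.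

Compound 3 `O=C(Nc1nc2ccc(Cl)cc2s1)C1CCOC1` carries oxolan-3-yl in place of propyl on a carbonyl carbon, with the rest of compound 2 unchanged: oxolan-3-yl in place of propyl on a carbonyl carbon.

Going by the values given here, with no measured step to scale from, the expectation rests on the limit reached by compound 2 at > 50000 nM. No step beyond the scatter is expected in this assay, and no direction is favoured. The most likely report is again a limit rather than a number. The expected result of this change is a step that the limit leaves unreadable from compound 2 to compound 3. For compound 3 the estimated value is 60000 nM, with an expected range from 30000 nM to 120000 nM.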

Compound 3, half-maximal inhibitory concentration: > 50000 nM
Compound 3: a limit, no number (the forecaster's own chance of this, stated with the estimate: 85%); the middle value does not contradict the limit.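

In this assay compound 3 gives > 50000 nM, which is a limit and not a number. Compound 2 is also a limit, so no step from compound 2 to compound 3 can be read: the limit of > 50000 nM in this assay, at which 3 of the 3 values shown sit.

Still open, going by these compounds, is whether oxolan-3-yl in place of propyl on a carbonyl carbon changes anything in this assay, and whether any compound of the series gives a number there.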